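Replacing 4-hydroxyphenyl with thiophen-2-yl on the shared core

The source may report more compounds than this note shows. Statements on the series, on what has been measured and on what is new or still open speak of the compounds shown alone.

Measured in a functional assay on HT-29 cells (Homo sapiens) for inhibition, with a stated time of 72 h; on this read-out lower numbers stand for stronger inhibition and higher numbers for weaker inhibition:
Compound 1 `COc1ccc(S(=O)(=O)N2CCc3cccc(-c4ccc(N(C)C)cc4)c32)cc1` - 467 nM
Compound 2 `COc1ccc(-c2cccc3c2N(S(=O)(=O)c2ccc(OC)cc2)CC3)cc1` - 277 nM
Compound 3 `COc1ccc(S(=O)(=O)N2CCc3cccc(-c4ccc(O)cc4)c32)cc1` - 133 nM

Compound 3 gives the lowest of these numbers, and its gaps to the other two lie beyond the scatter. Compound 4 `COc1ccc(S(=O)(=O)N2CCc3cccc(-c4cccs4)c32)cc1` keeps the shared core but carries thiophen-2-yl in place of 4-hydroxyphenyl on an aromatic carbon, so it has no hydroxy group. Two measured steps arrive at that hydroxy group, both modest: a 2.1-fold lower number from compound 2 to compound 3 (0.32 log units; beyond the scatter) and a 3.5-fold lower number from compound 1 to compound 3 (0.55 log units; beyond the scatter). The third, a 1.7-fold lower number from compound 1 to compound 2 (0.23 log units; within the scatter), stays small. Among the measured compounds shown here, a modest step towards a higher number in this assay is therefore expected, although no measured compound holds this five-membered ring. The expected step is a 2.3-fold higher number from compound 3 to compound 4 (0.35 log units; beyond the scatter). For compound 4 the estimated value is 300 nM, with an expected range of 110 nM to 800 nM.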

Compound 4, half-maximal inhibitory concentration: 200 nM
For compound 4 the middle estimate is 1.5-fold (0.18 log units) above the measured one; low and high end bracket the measured number.
By their numbers in this assay, from the lowest: compounds 3, 4, 2 and 1 (each within the scatter of the next, the first and the last beyond it).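

In this assay this aromatic carbon tolerates a five-membered sulfur ring without a hydroxy group: a 1.5-fold higher number from compound 3 to compound 4 (0.18 log units; within the scatter) and a 1.4-fold lower number from compound 2 to compound 4 (0.14 log units; within the scatter) both stay within the scatter, so the hydroxy group of compound 3 is not needed to reach this range. Only a 2.3-fold lower number from compound 1 to compound 4 (0.37 log units; beyond the scatter) lies beyond the scatter, and it is modest. No measured evidence accounts for these steps. Thiophen-3-yl, with its sulfur placed differently, remains open. So do a carboxylic acid or a saturated amine such as piperidine on this carbon.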